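A methylated indole group replaces the indazole in compound 3

The source may hold more compounds than are shown below. What is called first, only, known or untested is meant among the compounds shown, and "the series" means these compounds.

- compound 1 `CN1CCN(c2cccc(Nc3nccc(-c4cn(C)c5ncccc45)n3)c2)CC1`: 24 nM
- compound 2 `CC(=O)N1CCN(c2ccc(Nc3ncc(C#N)c(-c4c[nH]c5ccccc45)n3)cc2)CC1`: 4 nM
- compound 3 `CC(=O)N1CCN(c2ccc(Nc3ncc(C#N)c(-c4n[nH]c5ccccc45)n3)cc2)CC1`: 17 nM

These values come from a functional assay on MV4-11 cells (Homo sapiens) for antiproliferative activity, read by resazurin assay, with a stated time of 72 h; on this read-out lower numbers stand for stronger inhibition of growth and higher numbers for weaker inhibition of growth. There, compound 3 gives 17 nM, which lies within the usual scatter of compound 1 at 24 nM and clearly above compound 2 at 4 nM.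

The next compound is compound 4 `CC(=O)N1CCN(c2ccc(Nc3ncc(C#N)c(-c4cn(C)c5ccccc45)n3)cc2)CC1`, which has 1-methyl-1H-indol-3-yl in place of 1H-indazol-3-yl on an aromatic carbon, ortho to a cyano group. Counted out, the difference is 1-methyl-1H-indol-3-yl in place of 1H-indazol-3-yl on an aromatic carbon.

Going by the values given here, one measured step bears on this change: a 4.3-fold higher number from compound 2 to compound 3 (0.63 log units; beyond the scatter). In that step 1H-indazol-3-yl replaced 1H-indol-3-yl, and the number rose. Among the compounds with values here, compound 4 undoes part of that swap, since its group is the methylated form of the one in compound 2. Within the data shown here, no measured pair shows what the added methyl does alone, and compound 1 differs from the others in too many places to show it. A partial return towards compound 2 therefore seems the fair expectation, smaller than the measured step. The expected change is a 1.9-fold lower number from compound 3 to compound 4 (0.28 log units; within the scatter) in this assay. For compound 4 the estimated value is 9 nM, with an expected range from 3 nM to 28 nM.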

Compound 4, concentration for 50% growth inhibition: 30 nM
For compound 4 the middle estimate is 3.3-fold (0.52 log units) below the measured one; measured number above the stated range.
By their numbers in this assay, from the lowest: compound 2; then compounds 3, 1 and 4 (each within the scatter of the next).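

In this assay, going by these compounds alone, the step of a 7.5-fold higher number from compound 2 to compound 4 (0.88 log units; beyond the scatter) is the first measured sign that putting methyl in place of hydrogen on the aromatic nitrogen of the 1H-indol-3-yl group costs activity at this position, ortho to a cyano group, so compound 2 remains the only one of the three groups here to stand clearly apart. Replacing 1H-indazol-3-yl with 1-methyl-1H-indol-3-yl gives a 1.8-fold higher number from compound 3 to compound 4 (0.25 log units; within the scatter) and leaves the two compounds within the usual scatter, even though the group in compound 3 has a hydrogen-bond donor and the group in compound 4 has none, so counting donors does not separate this pair. Nothing measured on these compounds explains either result.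

The compounds shown leave open whether a longer chain on that same ring nitrogen, such as ethyl or a chain ending in an amine, would behave like methyl or move the number further. They also leave open whether methyl on this nitrogen has a similar effect on the core of compound 1, which has no partner carrying hydrogen there.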